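A few compounds are considered here, and "the series" means these few. Any claim that something is new, unique, unknown or untested is made for them only; others in the source may bear on it.

Measured so far in a functional assay on HEK293 cells for agonist activity at lutropin-choriogonadotropic hormone receptor (Homo sapiens), read by cAMP accumulation; on this read-out lower numbers stand for smaller maximal responses and higher numbers for larger maximal responses:
- compound 1 `COc1cccc(-c2nc(SC)nc3sc(C(=O)NCC#N)c(N)c23)c1`: 20.3%
- compound 2 `CCNC(=O)c1sc2nc(SC)nc(-c3cccc(OC)c3)c2c1N`: 26.9%

Going by the values given here, compound 2 is within the scatter of compound 1, the only other compound measured. Among the compounds with values here, the one known step, a number 6.6 percentage points higher from compound 1 to compound 2 (within the scatter), lies within the scatter. Compound 3 `COc1cccc(-c2nc(SC)nc3sc(C(=O)N(C)C)c(N)c23)c1` differs from compound 2 by dimethylamino in place of ethylamino on a carbonyl carbon. Within the data shown here, no measured step covers a change of this kind, so the expected step of a number 1.9 percentage points lower from compound 2 to compound 3 (within the scatter) is taken as none beyond the scatter. Compound 3 is therefore estimated at 25% in this assay, with a range of 8% to 45%.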

Compound 3, largest response reached (reported as efficacy), in percent of the reference or control that the assay uses: 11%
Estimate against measurement, compound 3: 14 percentage points above; the measured number falls inside the stated range.
By their numbers in this assay, from the lowest: compounds 3, 1 and 2 (each within the scatter of the next, the first and the last beyond it).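

In this assay, going by these compounds alone, dimethylamino in place of ethylamino on a carbonyl carbon gives a number 15.9 percentage points lower from compound 2 to compound 3 (beyond the scatter) and is the first step here to pass beyond the scatter, so this position can respond to what sits on the amide nitrogen. Dimethylamino in place of (cyanomethyl)amino gives a number 9.3 percentage points lower from compound 1 to compound 3 (within the scatter) so the change registers clearly against only one of the two groups. Nothing available explains this difference.

Methylamino, which keeps the amide hydrogen with a smaller group, remains open. So do a longer chain and a ring amine such as pyrrolidine at this carbonyl carbon.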